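Swapping the Aryl Group for Cyclohexyl on the Ring Nitrogen

The compounds below may be only part of what the source reports. "The series", "measured", "known", "first", "only" and "open" are said of these compounds alone.

Compound 1 `O=C1NC2(CC2c2ccc3cccc(OCc4ccccc4)c3n2)C(=O)N1c1ccc(C(F)(F)F)cc1` is tested in a functional assay on the whole organism (strain Kunming) with Mus musculus as the target, in the maximal electroshock model, with a stated time of 0.5 h (on this read-out higher numbers stand for an effect only at larger amounts of compound and lower numbers for an effect already at smaller amounts), where compound 1 gives 300 mg/kg. Compound 2 `CC(C)N1C(=O)NC2(CC2c2ccc3cccc(OCc4ccccc4)c3n2)C1=O` gives 300 mg/kg and compound 3 `Cc1ccc(N2C(=O)NC3(CC3c3ccc4cccc(OCc5ccccc5)c4n3)C2=O)cc1` gives 100 mg/kg; compound 1 thus stands level with compound 2 at the highest number of the three, while a 3.0-fold lower number from compound 1 to compound 3 (0.48 log units; beyond the scatter) separates it from compound 3. Compound 4 `O=C1NC2(CC2c2ccc3cccc(OCc4ccccc4)c3n2)C(=O)N1C1CCCCC1` differs from compound 1 in one place: cyclohexyl in place of 4-(trifluoromethyl)phenyl on an amide-type nitrogen in a ring. The step that bears most on this is no change at the digits printed from compound 1 to compound 2 (within the scatter), which also removed the 4-(trifluoromethyl)phenyl from that nitrogen; a 3.0-fold lower number from compound 2 to compound 3 (0.48 log units; beyond the scatter) went the other way. A step of about no change at the digits printed from compound 1 to compound 4 (within the scatter) is therefore expected, with no change beyond the scatter. Compound 4 is estimated at 300 mg/kg, in a range from 100 mg/kg to 600 mg/kg.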

Compound 4, minimum effective dose: 300 mg/kg
For compound 4 middle estimate and measured number coincide at the digits printed, and the stated range covers the measured number.
By their numbers in this assay, from the lowest: compound 3; then compounds 1, 2 and 4 (each within the scatter of the next).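

In this assay the non-aromatic cyclohexyl on the ring nitrogen performs like the two earlier groups, with no change at the digits printed from compound 1 to compound 4 (within the scatter) and no change at the digits printed from compound 2 to compound 4 (within the scatter) on record. Against 4-methylphenyl, cyclohexyl gives a 3.0-fold higher number from compound 3 to compound 4 (0.48 log units; beyond the scatter) and so does not share the lower number of compound 3, though compound 1 shows that an aromatic ring alone does not bring that number. No measurement shown explains these results.

Still open, from the compounds shown here alone, is whether a carboxylic acid or an amine-bearing chain on this nitrogen would shift the number. Going by these compounds, it is also open whether methoxy or chlorine in place of the methyl of compound 3 would keep it low.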